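Lengthening the amide chain from isobutyl to pentyl

A few compounds are considered here, and "the series" means these few. Any claim that something is new, unique, unknown or untested is made for them only; others in the source may bear on it.

In a functional assay on U-937 cells (Homo sapiens) for cytotoxicity, read by MTT assay, with a stated time of 48 h (on this read-out higher numbers stand for weaker inhibition and lower numbers for stronger inhibition), compound 1 (`NC(=O)CC[C@H](NS(=O)(=O)c1ccc([N+](=O)[O-])cc1)C(=O)O`) returns > 500000 nM as its result, and this is a limit of the assay, not a number. Among the compounds with values here, compound 2 (`CC(C)CNC(=O)CC[C@H](NS(=O)(=O)c1ccc([N+](=O)[O-])cc1)C(=O)O`) gives 93800 nM as the only true number so far.

The next compound is compound 3 (`CCCCCNC(=O)CC[C@H](NS(=O)(=O)c1ccc([N+](=O)[O-])cc1)C(=O)O`). Its difference from compound 2 is butyl in place of isopropyl on a saturated chain carbon bound to an amide-type nitrogen in the outer part of the chain, which can also be read as isobutyl to pentyl on the amide nitrogen.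

Within the data shown here, only one measured step bears on this. Because an at least 5.3-fold lower number from compound 1 to compound 2 (0.72 log units; beyond the scatter) came with a whole new chain on compound 2, while compound 3 only reshapes and slightly extends that chain, a much smaller move is expected in this assay here, leaning towards a lower number and probably staying within the scatter. The expected change is a 1.3-fold lower number from compound 2 to compound 3 (0.13 log units; within the scatter) on this estimate. Compound 3 is estimated at 70000 nM (range 30000 nM to 170000 nM).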

Compound 3, half-maximal inhibitory concentration: 32100 nM
The estimate for compound 3 lay 2.2-fold (0.34 log units) above the measured number, within the range that was stated.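

Compound 2 already carried a chain on the amide-type nitrogen, and the earlier step showed only what adding such a chain did. The new step shows that in this assay the form of that chain matters too, with butyl in place of isopropyl on a saturated chain carbon bound to an amide-type nitrogen giving a 2.9-fold lower number from compound 2 to compound 3 (0.47 log units; beyond the scatter). Set against the amide hydrogen, pentyl gives an at least 15-fold lower number from compound 1 to compound 3 (1.19 log units; beyond the scatter), and this step can be read only as a bound, as compound 1 stands at a limit and not at a number: the limit of > 500000 nM in this assay, at which 1 of the 3 values shown sits.

The change from isobutyl to pentyl both adds a carbon and removes the branch, and these compounds do not separate the two; an unbranched butyl or a branched isopentyl chain on the same nitrogen would tell them apart. Also open, as far as these compounds go, is how the read-out moves with a longer chain such as octyl, with a ring such as benzyl on that nitrogen, or with an amine at the far end of the pentyl chain.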